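Hydroxy on the lactam ring carbon of compound 1

The source may hold more compounds than are shown below. What is called first, only, known or untested is meant among the compounds shown, and "the series" means these compounds.

Compound 1 `CO[C@@H]1[C@@H](O)[C@@H](O)[C@H]2O[C@]1(C)n1c3ccccc3c3c4c(c5c6ccccc6n2c5c31)C(=O)NC4` gives 1010 nM in an assay on isolated protein for inhibition of protein kinase C theta type (Homo sapiens), read by HTRF; a higher number here means a weaker inhibitor, a lower number a stronger inhibitor. Among the three measured compounds it holds the second highest number; compound 2 `CO[C@H]1C(=O)C[C@H]2O[C@]1(C)n1c3ccccc3c3c4c(c5c6ccccc6n2c5c31)C(=O)NC4` gives 560 nM and compound 3 `C[C@]12O[C@H](C[C@]1(O)C(=O)O)n1c3ccccc3c3c4c(c5c6ccccc6n2c5c31)C(=O)NC4=O` gives 1860 nM, and both of these numbers lie within the usual scatter of the value of compound 1, so no order among the three can be read from them. Compound 4 `CO[C@@H]1[C@@H](O)[C@@H](O)[C@H]2O[C@]1(C)n1c3ccccc3c3c4c(c5c6ccccc6n2c5c31)C(=O)N[C@H]4O` is the unmeasured analogue: hydroxy in place of hydrogen on a saturated ring carbon. No measured pair shows this change, so its effect is unknown from the data shown. The expected step of a 1.2-fold higher number from compound 1 to compound 4 (0.07 log units; within the scatter) is small, with no direction beyond the scatter. Compound 4 is estimated at 1200 nM in this assay, within a range of 500 nM to 3000 nM.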

Compound 4, half-maximal inhibitory concentration: 2250 nM
The estimate for compound 4 lay 1.9-fold (0.27 log units) below the measured number, within the range that was stated.
By their numbers in this assay, from the lowest: compounds 2, 1, 3 and 4 (each within the scatter of the next, the first and the last beyond it).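

In this assay, for the compounds shown here, hydroxy in place of hydrogen on the saturated ring carbon next to the ring nitrogen gives a 2.2-fold higher number from compound 1 to compound 4 (0.35 log units; beyond the scatter) and is the first single-place change. The step is modest but beyond the scatter, so this position responds to substitution, and this change moves the number upward. Nothing available explains the step.

From the compounds shown here alone, whether other groups on this carbon behave alike remains open; a methyl or an amine would test this. The effect of the opposite configuration at this carbon is also unresolved.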